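A few compounds are considered here, and "the series" means these few. Any claim that something is new, unique, unknown or untested is made for them only; others in the source may bear on it.

Of the compounds shown here, three sharing one core have been measured in a functional assay on the whole organism (muscle tissue) with Rattus norvegicus as the target; a lower number here means a smaller maximal response, a higher number a larger maximal response. Compound 1 `CNC(=O)C1=CC(C)(C)Oc2ccc(C#N)cc21` gives 66.6%. Compound 2 `CCCNC(=O)C1=CC(C)(C)Oc2ccc([N+](=O)[O-])cc21`, with a nitro group in place of the nitrile, gives 74.1%. Compound 3 `CCCCNC(=O)C1=CC(C)(C)Oc2ccc([N+](=O)[O-])cc21` gives 83.2%, which is the highest of the three numbers; the nearest is compound 2, at a gap within the scatter, and the furthest is compound 1, at a gap beyond the scatter. Among the measured compounds shown here, the only measured step that bears on compound 4 is a number 9.1 percentage points higher from compound 2 to compound 3 (within the scatter).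

Compound 4 `CC1(C)C=C(C(=O)NCC2CC2)c2cc([N+](=O)[O-])ccc2O1` differs from compound 3 in one place: cyclopropyl in place of propyl on a saturated chain carbon bound to an amide-type nitrogen. The leaving and entering groups carry the same count of heavy atoms, the difference being that the entering group closes into a three-membered ring. Since lengthening the chain on the amide-type nitrogen from compound 2 to compound 3 moved the intrinsic activity only within the scatter, rearranging the same three carbons into a ring is not expected to move it beyond the scatter either. Compound 4 is therefore estimated to reach 80%, within a range from 68% to 92%, an expected step of a number 3.2 percentage points lower from compound 3 to compound 4 (within the scatter).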

Compound 4, intrinsic activity: the largest response reached, in percent of the reference agonist's: 89.3%
Compound 4: middle estimate off by 9.3 percentage points, on the low side; low and high end bracket the measured number.
By their numbers in this assay, from the lowest: compounds 1, 2, 3 and 4 (each within the scatter of the next, the first and the last beyond it).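

In this assay, closing the three carbons of the propyl group into a cyclopropyl ring at this saturated chain carbon gives a number 6.1 percentage points higher from compound 3 to compound 4 (within the scatter), so a three-membered ring of the same heavy-atom count is accommodated here without a step that can be told from the scatter. Set against the propyl-to-ethyl comparison that the earlier compounds allowed, the new comparison with the nitro group held constant gives a number 15.2 percentage points higher from compound 2 to compound 4 (beyond the scatter), the first change on the amide-type nitrogen's substituent to pass beyond the scatter, even though compound 3 stays within the scatter of both compound 2 and compound 4. Nothing available explains why the cyclopropyl compound differs from the shorter chain in this read-out.

The compounds shown leave open whether a larger ring such as cyclobutyl or a longer chain such as pentyl on the same carbon would keep the maximal response in this range. They also leave open whether the cyclopropyl group would give a similar number on the core of compound 1, which carries a nitrile in place of the nitro group.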